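A few compounds are considered here, and "the series" means these few. Any claim that something is new, unique, unknown or untested is made for them only; others in the source may bear on it.

Measured in a physicochemical assay for lipophilicity, using the shake flask method, in phosphate buffer, measured as octanol-water partition, with a stated time of 30 min, at pH 7.4; on this read-out higher numbers stand for higher lipophilicity and lower numbers for lower lipophilicity:
compound 1 `CN(c1ccn(C)n1)c1cnc(NCc2c(F)ccc3c2CCO3)c2cn[nH]c(=O)c12`: 2.4
compound 2 `CNC(=O)c1cc(-c2cnc(NCc3c(F)ccc4c3CCO4)c3cn[nH]c(=O)c23)n(C)n1`: 2.1
compound 3 `CNC(=O)c1ncc(-c2cnc(NCc3c(F)ccc4c3CCO4)c3cn[nH]c(=O)c23)n1C`: 2.5

Compound 3 carries the highest of the three numbers, though its gap to compound 1 lies within the scatter and only its gap to compound 2 lies beyond it. Compound 4 `Cc1nc(CO)ccc1-c1cnc(NCc2c(F)ccc3c2CCO3)c2cn[nH]c(=O)c12` is not yet measured. It differs from compound 3 in one place: 6-(hydroxymethyl)-2-methylpyridin-3-yl in place of 1-methyl-2-(methylcarbamoyl)-1H-imidazol-5-yl on an aromatic carbon. Within the data shown here, the steps that bear on this position are a number 0.40 log units higher from compound 2 to compound 3 (beyond the scatter) and a number 0.10 log units higher from compound 1 to compound 3 (within the scatter), both exchanges of the group on the same aromatic carbon, and all three measured steps are small. Among the measured compounds shown here, no measured step covers a six-membered ring at this place, so the direction stays open. The step is expected to stay within the scatter, a number 0.10 log units lower from compound 3 to compound 4 (within the scatter). The estimate for compound 4 is 2.4, range 1.9 to 2.9.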

Compound 4, distribution coefficient: 2.4
Compound 4: the middle estimate sits on the measured number at the digits printed; low and high end bracket the measured number.
By their numbers in this assay, from the lowest: compounds 2, 1, 4 and 3 (each within the scatter of the next, the first and the last beyond it).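

In this assay the first six-membered aromatic ring on this aromatic carbon, 6-(hydroxymethyl)-2-methylpyridin-3-yl, leaves the read-out within the scatter of all three earlier groups (a number 0.10 log units lower from compound 3 to compound 4 (within the scatter); a number 0.30 log units higher from compound 2 to compound 4 (within the scatter); no change at the digits printed from compound 1 to compound 4 (within the scatter)). Ring size and the kind of group on this carbon therefore give no readable step here, and the only step beyond the scatter remains the one between the two methylcarbamoyl azoles (a number 0.40 log units higher from compound 2 to compound 3 (beyond the scatter)).

From the compounds shown here alone, whether an amine or a carboxylic acid in place of the hydroxymethyl would move this number remains open. Nothing to hand explains these values.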